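Swapping a Hydroxyl Tail for a Sulfonate on the Amide

A few compounds are considered here, and "the series" means these few. Any claim that something is new, unique, unknown or untested is made for them only; others in the source may bear on it.

Compound 1, `CCCCCCCCCCCC(=O)OC[C@H](CSC[C@@H](N)C(=O)NC(C)(C)CO)OC(=O)CCCCCCCCCCC`: 15500 nM
Compound 2, `CCCCCCCCCCCC(=O)OC[C@H](CSC[C@@H](N)C(=O)NCCO)OC(=O)CCCCCCCCCCC`: 24 nM
Compound 3, `CCCCCCCCCCCC(=O)OC[C@H](CSC[C@@H](N)C(=O)NCCCCCCO)OC(=O)CCCCCCCCCCC`: 33 nM

All three share one core and differ only in the group on the amide-type nitrogen. In an assay on HEK293 cells for agonist activity at Toll-like receptor 2 (Homo sapiens) (on this read-out lower numbers stand for an effect already at smaller amounts and higher numbers for an effect only at larger amounts of compound), compound 2 and compound 3 sit together within the scatter (a 1.4-fold higher number from compound 2 to compound 3 (0.14 log units; within the scatter)), while compound 1 stands far apart from both (a 650-fold lower number from compound 1 to compound 2 (2.81 log units; beyond the scatter), a 470-fold lower number from compound 1 to compound 3 (2.67 log units; beyond the scatter)). Compound 4, `CCCCCCCCCCCC(=O)OC[C@H](CSC[C@@H](N)C(=O)NCCCS(=O)(=O)O)OC(=O)CCCCCCCCCCC`, comes from compound 2 by sulfomethyl in place of hydroxy on a saturated chain carbon, two bonds along the chain from an amide-type nitrogen. Among the compounds with values here, the step from compound 2 to compound 3 bears most directly on this change, since it also lengthens the chain at the same place with little effect; no measured step tests an acid group, so this part is uncertain. The expected step is a 2.5-fold higher number from compound 2 to compound 4 (0.40 log units; beyond the scatter). Compound 4 is therefore estimated at 60 nM, ranging from 10 nM to 400 nM.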

Compound 4, half-maximal effective concentration: 5560 nM
The estimate for compound 4 lay 93-fold (1.97 log units) below the measured number; measured number outside the range, above it.
By their numbers in this assay, from the lowest: compounds 2 and 3 (each within the scatter of the next); then compound 4; then compound 1.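

A sulfo group at the chain end gives a 230-fold higher number from compound 2 to compound 4 (2.36 log units; beyond the scatter) and a 170-fold higher number from compound 3 to compound 4 (2.23 log units; beyond the scatter) even though the 2-hydroxyethyl and 6-hydroxyhexyl chains sit within the scatter of each other, so at this position the end group counts for far more than chain length. The 1-(hydroxymethyl)-1-methylethyl group still gives the highest number, and a 2.8-fold lower number from compound 1 to compound 4 (0.45 log units; beyond the scatter) is a modest step that lies beyond the scatter. Nothing shown explains why the sulfo group raises the number so sharply. From the compounds shown here alone, whether a carboxylic acid or an amine at the chain end would behave like the sulfo group or like the hydroxy group stays open.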